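Fluorine shift on the aryl group of compound 2

The source may hold more compounds than are shown below. What is called first, only, known or untested is meant among the compounds shown, and "the series" means these compounds.

For the measured compounds named here, in an ADME assay on microsomes from liver (Homo sapiens) for metabolic stability, read by LC-MS (on this read-out higher numbers stand for a longer-lived compound and lower numbers for a shorter-lived compound), compound 2 `O=C(Nc1ccc(F)c(-c2nc3ncc(-c4ccc(F)cc4)cc3[nH]2)c1)N1CCCC1` gives 0.203 h, the only actual number so far. Compound 1 `Cc1nc(C)c(C(=O)Nc2ccc(F)c(-c3nc4ncc(-c5cccnc5Cl)cn4n3)c2)o1` gives > 1.5 h, which is a limit of the assay. Compound 3 `Cc1nc(C)c(C(=O)Nc2ccc(F)c(-c3nc4ncc(-c5ccccc5Cl)cn4n3)c2)o1` gives > 1.5 h, also a limit. Compound 4 `O=C(Nc1ccc(F)c(-c2nc3ncc(-c4cccc(F)c4)cc3[nH]2)c1)N1CCCC1` differs from compound 2 as follows: 3-fluorophenyl in place of 4-fluorophenyl on an aromatic carbon. Going by the values given here, the one measured step, a step that the two limits leave unreadable from compound 1 to compound 3, sits on another core and offers no size to carry over. The expectation therefore rests on compound 2 at 0.203 h, with no change expected in this assay beyond the scatter. The estimated step is a 1.0-fold lower number from compound 2 to compound 4 (0.01 log units; within the scatter). For compound 4 the estimate is 0.2 h, with an expected range of 0.09 h to 0.45 h.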

Compound 4, half-life: 0.185 h
The estimate for compound 4 lay 1.1-fold (0.03 log units) above the measured number; the measured number falls inside the stated range.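

In this assay, for the compounds shown here, the swap of 4-fluorophenyl for 3-fluorophenyl gives a 1.1-fold lower number from compound 2 to compound 4 (0.04 log units; within the scatter) and so provides the first readable step at this position on the shared core. The two fluorophenyl groups read alike here, which the earlier step between two limits could not show. No measurement shown bears on why the half-life stays put at this position.

Going by these compounds, whether an amine or a carboxylic acid on this aromatic ring would shift the half-life remains open. So does the reading for an unsubstituted phenyl at this position.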